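This account rests on a few compounds, and the source may have more. Where it says the series, first, only, none or still open, it means among the compounds named here.

Among the measured compounds shown here, compound 1 `CN(CCNCc1cn(-c2ccc(F)cc2)nn1)CCNc1ccnc2cc(Cl)ccc12` gives 19000 nM in a functional assay on HCC827 cells (Homo sapiens) for antiproliferative activity, read by sulforhodamine B assay, with a stated time of 72 h; on this read-out lower numbers stand for stronger inhibition and higher numbers for weaker inhibition; compound 2 `CN(CCNCc1cn(Cc2ccc(Br)cc2)nn1)CCNc1ccnc2cc(Cl)ccc12` gives 9300 nM in this assay, the lower of the two numbers, and the sole measured step, a 2.0-fold lower number from compound 1 to compound 2 (0.31 log units; beyond the scatter), is the only guide. Compound 3 `CN(CCNCc1cn(CCC(=O)Nc2ccccn2)nn1)CCNc1ccnc2cc(Cl)ccc12` carries ((pyridin-2-yl)carbamoyl)methyl in place of 4-bromophenyl on a saturated chain carbon bound to an aromatic nitrogen. For the measured compounds named here, the measured step exchanged one group on the aromatic nitrogen for another and gave a modest change; the present change removes the 4-bromophenyl altogether, so no measured step bears on it directly, and no step beyond the scatter is expected in this assay. Compound 3 is estimated at 12000 nM, between 5000 nM and 30000 nM. The expected step is a 1.3-fold higher number from compound 2 to compound 3 (0.11 log units; within the scatter).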

Compound 3, half-maximal inhibitory concentration: > 200000 nM
Compound 3 was reported as a limit (the forecaster's own chance of this, stated with the estimate: 10%); middle value at least 16-fold (1.22 log units) away from the limit.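

Compound 3 stands at a limit of the assay, not at a number: the limit of > 200000 nM in this assay, at which 1 of the 3 values shown sits. Where 4-fluorophenyl and 4-bromobenzyl on the aromatic nitrogen differed only modestly, 2-((pyridin-2-yl)carbamoyl)ethyl brings an at least 21-fold higher number from compound 2 to compound 3 (1.33 log units; beyond the scatter) and an at least 10-fold higher number from compound 1 to compound 3 (1.02 log units; beyond the scatter). This position is therefore not indifferent to the group it carries, and the change can cost far more than the earlier step showed.

The compounds shown do not separate the contributions of the carbamoyl link, the pyridin-2-yl ring and the chain. A 2-phenylethyl group or a simple primary amide on the same chain would begin to separate them.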